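Adding Isobutyl to the Nitro Analogue: Expected Inhibition

The source may report more compounds than this note shows. Statements on the series, on what has been measured and on what is new or still open speak of the compounds shown alone.

Three compounds have been measured in a functional assay for inhibition, read by spectrophotometry, with a stated time of 20 min, tested at 2 mg/mL; a higher number here means a stronger effect of the compound at the concentration tested, a lower number a weaker effect:

Compound 1, `CC(=O)c1ccc(NC(=O)CN(C(=O)c2ccccc2)S(=O)(=O)c2ccc(C)cc2)cc1`, gives 18.1%.
Compound 2, `CC(=O)c1ccc(NC(=O)C(CC(C)C)N(C(=O)c2ccccc2)S(=O)(=O)c2ccc(C)cc2)cc1`, gives 58.1%.
Compound 3, `CC(=O)c1ccc(NC(=O)CN(C(=O)c2ccccc2)S(=O)(=O)c2ccc([N+](=O)[O-])cc2)cc1`, gives 20.6%.

Compound 3 stands second highest of these three numbers. Its nearest neighbour is reached by an exchange that stays within the usual scatter: a number 2.5 percentage points higher from compound 1 to compound 3 (within the scatter), from nitro in place of methyl on an aromatic carbon. The furthest neighbour is reached by a step far beyond the scatter: a number 40 percentage points higher from compound 1 to compound 2 (beyond the scatter), from isobutyl in place of hydrogen on a saturated chain carbon bound to an amide-type nitrogen and a carbonyl carbon.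

Compound 4, `CC(=O)c1ccc(NC(=O)C(CC(C)C)N(C(=O)c2ccccc2)S(=O)(=O)c2ccc([N+](=O)[O-])cc2)cc1`, has not yet been measured. It differs from compound 3 by isobutyl in place of hydrogen on a saturated chain carbon bound to an amide-type nitrogen and a carbonyl carbon. Among the measured compounds shown here, only one measured step bears on this, and it is of the same kind: a number 40 percentage points higher from compound 1 to compound 2 (beyond the scatter), large and upward. The nitro-for-methyl exchange on its own stayed within the scatter, so nothing in the data suggests the isobutyl step should behave differently when nitro is present. For compound 4 the expected step is therefore a number 39.4 percentage points higher from compound 3 to compound 4 (beyond the scatter) in this assay. The estimate for compound 4 is 60%, within a range from 42% to 78%.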

Compound 4, a percentage reported as inhibition, at one concentration (the size of the read-out at that concentration, not a potency): 54.2%
Estimate against measurement, compound 4: 5.8 percentage points above; low and high end bracket the measured number.
By their numbers in this assay, from the lowest: compounds 1 and 3 (each within the scatter of the next); then compounds 4 and 2 (each within the scatter of the next).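

In this assay, isobutyl in place of hydrogen on a saturated chain carbon bound to an amide-type nitrogen and a carbonyl carbon now gives a number 33.6 percentage points higher from compound 3 to compound 4 (beyond the scatter), so the large gain at this position no longer rests on a single pair of compounds, and the two readings agree: the same change on two cores in this assay, a number 40 percentage points higher (beyond the scatter) from compound 1 to compound 2 and a number 33.6 percentage points higher (beyond the scatter) from compound 3 to compound 4, 6.4 percentage points apart, within the scatter of two such steps. Nitro in place of methyl on an aromatic carbon, now read with isobutyl present, gives a number 3.9 percentage points lower from compound 2 to compound 4 (within the scatter), so this exchange stays small on both cores: the same change on two cores in this assay, a number 2.5 percentage points higher (within the scatter) from compound 1 to compound 3 and a number 3.9 percentage points lower (within the scatter) from compound 2 to compound 4, 6.4 percentage points apart, within the scatter of two such steps. Across these four compounds, each change keeps its size whichever form of the other is present, and none of the four goes against this.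

As far as these compounds go, only hydrogen and isobutyl appear on this chain carbon, so it remains open whether a shorter chain such as methyl, a benzyl group, or a chain ending in an amine or a carboxylic acid would give a similar gain. From the compounds shown here alone, each number is also a read-out at one concentration, so whether these compounds would show a stronger or weaker effect at any other concentration remains open, as does the effect of aromatic groups other than methyl and nitro, such as methoxy or chloro.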